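Branching the alkyl group on the shared core

The source may hold more compounds than are shown below. What is called first, only, known or untested is meant among the compounds shown, and "the series" means these compounds.

Compound 1 `CCCc1nc2c(OCc3ccccc3)cccn2c1N` and compound 2 `CC(C)c1nc2c(OCc3ccccc3)cccn2c1N` share one core and differ only in the alkyl group on an aromatic carbon. In a functional assay on the whole organism with Canis familiaris (Canis lupus familiaris) as the target, at a dose of 8 mg/kg by the oral route (a lower number here means a weaker effect, a higher number a stronger effect of the compound at the dose given), compound 1 gives 0% and compound 2 gives 0%. The step of no change at the digits printed from compound 1 to compound 2 (within the scatter) stays within the scatter, so compound 2 stands level with compound 1 on these numbers, and neither measured compound shows an effect at this dose.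

Compound 3 `CC(C)(C)c1nc2c(OCc3ccccc3)cccn2c1N` carries the branching one stage further: methyl in place of hydrogen on a saturated chain carbon bound to an aromatic carbon and two saturated chain carbons. Within the data shown here, the only measured step that bears on this, propyl to isopropyl, is no change at the digits printed from compound 1 to compound 2 (within the scatter) and moved nothing beyond the scatter. Among the measured compounds shown here, with both measured compounds reading alike and the one relevant step flat, the data give no direction for a further methyl at the same place. For compound 3 the step is therefore expected to stay within the scatter, a number 2 percentage points higher from compound 2 to compound 3 (within the scatter). In this assay compound 3 is estimated to give 2%, with an expected range from 0% to 15%.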

Compound 3, a percentage reported as inhibition, in the whole organism at one dose (the size of the read-out at that dose, not a potency): 0%
For compound 3 the middle estimate is 2 percentage points above the measured one; measured number inside the range.
By their numbers in this assay, from the lowest: compounds 1, 2 and 3 (each within the scatter of the next).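

In this assay, methyl in place of hydrogen on the saturated chain carbon gives no change at the digits printed from compound 2 to compound 3 (within the scatter), and tert-butyl in place of propyl on an aromatic carbon gives no change at the digits printed from compound 1 to compound 3 (within the scatter). The flat reading therefore no longer rests on a single pair: it now holds across propyl, isopropyl and tert-butyl, and the series shows no effect of branching at this place, even when taken as far as tert-butyl. Nothing available bears on why the read-out stays flat.

Still open, from the compounds shown here alone, is whether any group at this place can move the read-out at all, for instance an amine, a carboxylic acid or a longer chain in place of tert-butyl on the aromatic carbon. With a single dose in this assay, the data also cannot tell whether the three compounds would stay level at any other dose, so the flat result describes this dose and these three alkyl groups only.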